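The source may report more compounds than this note shows. Statements on the series, on what has been measured and on what is new or still open speak of the compounds shown alone.

Working notes on the series. Compound 1 `Clc1ccc(-c2csc(N/N=C/c3cccs3)n2)cc1` gives 97% in a functional assay, read by spectrophotometry, with a stated time of 15 min, tested at 100 ug/mL; on this read-out lower numbers stand for a weaker effect and higher numbers for a stronger effect at the one concentration tested. Compound 2 `Fc1ccc(-c2csc(N/N=C/c3ccc(Cl)cc3Cl)n2)cc1` gives 96% in this assay. Compound 3 `Fc1ccc(-c2csc(N/N=C/c3cccs3)n2)cc1` gives 97% in this assay, level with compound 1 at the digits shown, and the number for compound 2 sits within the scatter of both. Within the data shown here, the only single-point step so far, no change at the digits printed from compound 1 to compound 3 (within the scatter), concerns fluoro in place of chloro on an aromatic carbon. Compound 4 `Cc1ccc(-c2csc(N/N=C/c3cccs3)n2)cc1` differs from compound 3 by methyl in place of fluoro on an aromatic carbon. Among the measured compounds shown here, no measured step exchanges a halogen for methyl, so the expectation rests on the flat step no change at the digits printed from compound 1 to compound 3 (within the scatter) at this position, and the expected step is a number 1 percentage points lower from compound 3 to compound 4 (within the scatter), none beyond the scatter. Compound 4 is therefore estimated at 96%, in the range 89% to 99%.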

Compound 4, a percentage reported as inhibition, at one concentration (the size of the read-out at that concentration, not a potency): 98.1%
For compound 4 the middle estimate is 2.1 percentage points below the measured one; measured number inside the range.
By their numbers in this assay, from the lowest: compounds 2, 1, 3 and 4 (each within the scatter of the next).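

Methyl now joins the halogens at this position, on an aromatic carbon para to a large group: in this assay, the change from fluoro gives a number 1.1 percentage points higher from compound 3 to compound 4 (within the scatter), and the change from chloro gives a number 1.1 percentage points higher from compound 1 to compound 4 (within the scatter). Fluoro, chloro and methyl therefore cannot be told apart here, so this position has not yet separated a halogen from a carbon group. Nothing available bears on why these groups read alike. Still open, on these data alone, is how an amine, a carboxylic acid or a longer chain would read at this position. Also open, as far as these compounds go, is whether methyl reads the same with the other aromatic group of compound 2.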